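Nitrobenzenesulfonyl benzoxazepines: uracil to chloropurine on the ring carbon

The compounds below may be only part of what the source reports. "The series", "measured", "known", "first", "only" and "open" are said of these compounds alone.

Measured compounds:
compound 1 `O=c1cc[nH]c(=O)n1C1CN(S(=O)(=O)c2ccccc2[N+](=O)[O-])c2ccccc2CO1`, a functional assay on MCF7 cells (Homo sapiens) for antiproliferative activity (on this read-out higher numbers stand for weaker inhibition and lower numbers for stronger inhibition), 50900 nM
compound 2 `O=c1ccn(C2CN(S(=O)(=O)c3ccccc3[N+](=O)[O-])c3ccccc3CO2)c(=O)[nH]1`, this assay 45200 nM
compound 3 `COC(CN(c1ccccc1CO)S(=O)(=O)c1ccc([N+](=O)[O-])cc1)n1c(=O)cc[nH]c1=O`, this assay 55200 nM

All three numbers sit close together. Within the data shown here, the gap from compound 1 to compound 2, a 1.1-fold lower number from compound 1 to compound 2 (0.05 log units; within the scatter), is the only single-point step, and it exchanges one uracil attachment for the other on the saturated ring carbon without moving the read-out. Among the measured compounds shown here, compound 3 carries the open-chain core and the other nitro position, and its number is not separated from compound 2 beyond the scatter either; no step is defined for that pair. Compound 2 thus stands in the same band as compound 1 and compound 3.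

Compound 4 `O=[N+]([O-])c1ccccc1S(=O)(=O)N1CC(n2cnc3c(Cl)ncnc32)OCc2ccccc21` keeps the core of compound 2 and changes the heterocycle: a group of 10 heavy atoms (5 carbon, 4 nitrogen, 1 chlorine; one five-membered aromatic ring with 2 hetero atoms, one six-membered aromatic ring with 2 hetero atoms) in place of a group of 8 heavy atoms (4 carbon, 2 nitrogen, 2 oxygen; one six-membered aromatic ring with 2 hetero atoms), on a saturated ring carbon. For the measured compounds named here, no measured step touches this kind of exchange; the one step in hand, from compound 1 to compound 2, swapped two closely related six-membered heterocycles and stayed within the scatter. There is no basis for expecting a movement beyond the scatter in either direction, though the uncertainty is wide. For compound 4 the estimate in this assay is 35000 nM, between 6000 nM and 150000 nM, an expected step of a 1.3-fold lower number from compound 2 to compound 4 (0.11 log units; within the scatter).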

Compound 4, half-maximal inhibitory concentration: 2100 nM
The estimate for compound 4 lay 17-fold (1.22 log units) above the measured number, outside the stated range (below it).
By their numbers in this assay, from the lowest: compound 4; then compounds 2, 1 and 3 (each within the scatter of the next).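

In this assay, the saturated ring carbon next to the ring oxygen proves sensitive to the group it carries: chloropurine in place of uracil gives a 22-fold lower number from compound 2 to compound 4 (1.33 log units; beyond the scatter) and a 24-fold lower number from compound 1 to compound 4 (1.38 log units; beyond the scatter), whereas the two uracil attachments alone gave only a 1.1-fold lower number from compound 1 to compound 2 (0.05 log units; within the scatter). The exchange changes several things at once, as the entering group adds a five-membered aromatic ring and a chlorine and has no hydrogen-bond donors or double bonds outside aromatic rings, so these steps cannot assign the shift to any one of these features. No available evidence bears on the origin of the shift.

The compounds shown leave open whether the chlorine itself matters, since no analogue here carries an amine, a methoxy group or a hydrogen at that place on the same two-ring heterocycle. They also leave open whether the chloropurine exchange would give a similar step on the open-chain core of compound 3, which carries the other nitro position and for which only the uracil form appears.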